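Removing the chloro from compound 2: an expected step in lipophilicity

The source may report more compounds than this note shows. Statements on the series, on what has been measured and on what is new or still open speak of the compounds shown alone.

Compound 2, `CCCc1nc2ccccc2c(=O)n1/N=C/c1ccc(Oc2ccc(Cl)cc2)cc1`, gives 5.78 in a physicochemical assay for lipophilicity, in phosphate buffer, measured as octanol-water partition; a higher number here means a more lipophilic compound, a lower number a more polar compound. Among the three measured compounds it stands second highest: compound 3, `O=c1c2ccccc2nc(-c2ccccc2)n1/N=C/c1ccc(Oc2ccc(Cl)cc2)cc1`, lies at 6.38, and a number 0.60 log units higher from compound 2 to compound 3 (beyond the scatter); compound 1, `Cc1nc2ccccc2c(=O)n1/N=C/c1ccc(Oc2ccc([N+](=O)[O-])cc2)cc1`, lies far lower at 4.01, though it differs from compound 2 in two places, so no single step is shown. Compound 4, `CCCc1nc2ccccc2c(=O)n1/N=C/c1ccc(Oc2ccccc2)cc1`, differs from compound 2 in one place: hydrogen in place of chloro on an aromatic carbon. No measured step matches this change; the only shown step concerns the phenyl in place of propyl. Loss of a chlorine from a carbon-only aromatic ring is generally expected to lower this assay by a modest amount. Compound 4 is therefore estimated at 5.1, within 4.7 to 5.5, an expected step of a number 0.68 log units lower from compound 2 to compound 4 (beyond the scatter).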

Compound 4, partition coefficient: 5.2
Compound 4: middle estimate off by 0.10 log units, on the low side, and the stated range covers the measured number.
By their numbers in this assay, from the lowest: compound 1; then compound 4; then compound 2; then compound 3.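

In this assay, the change from 4-chlorophenoxy to phenoxy gives the first step read at this place, on the aromatic carbon para to a large group: a number 0.58 log units lower from compound 2 to compound 4 (beyond the scatter). Among these compounds, the chloro here therefore makes a modest difference that lies beyond the scatter, whereas the only earlier step concerned the propyl. Nothing shown explains the size of this step. On these data alone, whether an amine or a carboxylic acid at this place would shift the number remains open. The share of the nitro in compound 1 also stays unresolved, since that compound differs from compound 2 in two places.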